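A few compounds are considered here, and "the series" means these few. Any claim that something is new, unique, unknown or untested is made for them only; others in the source may bear on it.

The measured compounds, each in a functional assay on THP-1 cells (Homo sapiens) for cytotoxicity, read by sulforhodamine B assay, with a stated time of 48 h; a higher number here means a weaker inhibitor, a lower number a stronger inhibitor:

Compound 1, `COc1cc(/C=C/C(=O)/C=C/c2cc(OC)c(OC)c(OC)c2)ccc1OCc1cn(CCOc2cc(=O)oc3ccccc23)nn1`: compound 1 gives 820 nM.
Compound 2, `COc1ccc(/C=C/C(=O)/C=C/c2ccc(OCc3cn(CCOc4cc(=O)oc5ccccc45)nn3)c(OC)c2)cc1OC`: compound 2 gives 2340 nM.
Compound 3, `COc1ccc(/C=C/C(=O)/C=C/c2ccc(OCc3cn(CCCOc4cc(=O)oc5ccccc45)nn3)c(OC)c2)cc1OC`: compound 3 gives 8510 nM.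

Compound 2 and compound 1 differ in one place only: methoxy in place of hydrogen on an aromatic carbon. This change gave a 2.9-fold lower number from compound 2 to compound 1 (0.46 log units; beyond the scatter), a modest step and one that lies beyond the usual scatter of the measurement. Compound 3 gives the highest of the three numbers; against compound 2 its value is higher by a margin beyond the scatter, and against compound 1 the gap is wider still. The difference between the core of compound 2 and the core of compound 3 is not broken down here.

The unmeasured compound 4, `COc1cc(/C=C/C(=O)/C=C/c2cc(OC)c(OC)c(OC)c2)ccc1OCc1cn(CCCOc2cc(=O)oc3ccccc23)nn1`, stands to compound 3 as compound 1 stands to compound 2: methoxy in place of hydrogen on an aromatic carbon. The surroundings of the changed position read the same for both pairs, so this is the same change made on a second core. Within the data shown here, for compound 4 in this assay, the expectation is that the same change brings the number down by about as much as before, that is a 2.8-fold lower number from compound 3 to compound 4 (0.45 log units; beyond the scatter), because the earlier step of a 2.9-fold lower number from compound 2 to compound 1 (0.46 log units; beyond the scatter) is the only measured guide to this change, and nothing here shows the second core answering differently. The expected value for compound 4 in this assay is therefore 3000 nM, estimated to lie between 1400 nM and 6500 nM.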

Compound 4, half-maximal inhibitory concentration: 5430 nM
Beside the measured number, compound 4's estimate is 1.8-fold (0.26 log units) below it; measured number inside the range.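

In this assay, methoxy in place of hydrogen, which turns 3,4-dimethoxyphenyl into 3,4,5-trimethoxyphenyl, gave a 1.6-fold lower number from compound 3 to compound 4 (0.20 log units; within the scatter) on the second core, so there the effect of the change cannot be told apart from the scatter of repeated measurements. Set beside the step on the first core, which lay beyond the scatter, it still gives no sign that the two cores answer differently: the same change on two cores in this assay, a 2.9-fold lower number (0.46 log units; beyond the scatter) from compound 2 to compound 1 and a 1.6-fold lower number (0.20 log units; within the scatter) from compound 3 to compound 4, 1.8-fold (0.26 log units) apart, within the scatter of two such steps. This shows that the measurements are compatible with the change carrying across these two cores at a similar size, but it does not show that the two steps are truly equal, nor that the change has a real effect on the second core, and one pair on each core is too little to establish a general rule for the series.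

The compounds shown leave open whether the step would hold up on a core with a longer chain between the triazole and the rest of the molecule, or in any cell line other than the one tested here. They also leave open how an amine or a carboxylic acid would compare with methoxy at the same aromatic carbon.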